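The source may hold more compounds than are shown below. What is called first, only, known or untested is meant among the compounds shown, and "the series" means these compounds.

Measured compounds:
- compound 1 `COc1cc(OC)c2c(=O)cc(-c3ccc(OCCF)cc3)oc2c1`, 21% in a functional assay (Homo sapiens) for antiproliferative activity, read by resazurin assay, with a stated time of 48 h, tested at 20 uM; on this read-out higher numbers stand for a stronger effect at the one concentration tested and lower numbers for a weaker effect
- compound 2 `COc1cc(OC)c2c(=O)cc(-c3ccc(OC4CCN(C)CC4)cc3)oc2c1`, "not determined" (no result reported) in this assay
- compound 3 `COc1cc(OC)c2c(=O)cc(-c3ccc(OCCCN)cc3)oc2c1`, "not determined" (no result reported) in this assay

Compound 1 is thus the only one of the three with a number, and that number is modest. Compound 4 `COc1cc(OC)c2c(=O)cc(-c3ccc(NCCN(C)C)cc3)oc2c1` keeps the shared core and the attached aromatic ring but carries a different group there: (2-(dimethylamino)ethyl)amino in place of 2-fluoroethoxy on an aromatic carbon. For the measured compounds named here, no measured pair shows how such a change moves this read-out, so the expectation rests on compound 1 alone. A moderate rise is expected, with the step from compound 1 to compound 4 estimated at a number 11 percentage points higher from compound 1 to compound 4 (beyond the scatter), which is close to the usual scatter. Compound 4 is therefore estimated at 32%, ranging from 8% to 62%.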

Compound 4, a percentage reported as inhibition, at one concentration (the size of the read-out at that concentration, not a potency): 84%
The estimate for compound 4 lay 52 percentage points below the measured number; measured number above the stated range.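

In this assay, putting (2-(dimethylamino)ethyl)amino in place of 2-fluoroethoxy gives a number 63 percentage points higher from compound 1 to compound 4 (beyond the scatter), so the group on this aromatic carbon can move the read-out strongly. The whole group changes in this one step, including the atom attached to the aromatic carbon and the end of the chain. Nothing shown explains the size of this step. Going by these compounds, it remains open whether the rise comes from the nitrogen attached to the aromatic carbon or from the dimethylamino end. A 2-(dimethylamino)ethoxy group, or a longer chain ending in dimethylamino, would help separate these two parts.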